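The source may hold more compounds than are shown below. What is called first, only, known or untested is meant among the compounds shown, and "the series" means these compounds.

Series notes. The shared core is held constant and the group attached to the oxygen is varied. In a functional assay for agonist activity at Free fatty acid receptor 1 (Homo sapiens), read by FLIPR, in the presence of a further agent that is not named here (a lower number here means that less compound is needed, a higher number that more compound is needed for the effect), compound 1 `O=C1NC(=O)C(Cc2ccc(Oc3cccc(Cl)c3)cc2)S1` gives 318 nM. Compound 2 `O=C1NC(=O)C(Cc2ccc(Oc3cc(Cl)cc(Cl)c3)cc2)S1` gives 207 nM, and compound 3 `O=C1NC(=O)C(Cc2ccc(Oc3ncccc3C(F)(F)F)cc2)S1` gives 2290 nM. Among the three numbers compound 1 sits close to compound 2, the step being a 1.5-fold lower number from compound 1 to compound 2 (0.19 log units; within the scatter), while compound 3 stands well apart from compound 1, beyond the scatter, as the one clearly higher number in the set.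

Compound 4 `O=C1NC(=O)C(Cc2ccc(Oc3ccc(Cl)cc3)cc2)S1` is not yet measured. It differs from compound 1 in one place: 4-chlorophenyl in place of 3-chlorophenyl on an oxygen on an aromatic ring. Among the measured compounds shown here, no measured step moves a chloro substituent from one aromatic carbon to another. For the measured compounds named here, the only single-change step in hand, a 1.5-fold lower number from compound 1 to compound 2 (0.19 log units; within the scatter), adds a second chloro and stays within the scatter, and the large rise to compound 3 comes with a different ring altogether. Going by the values given here, no measured step therefore bears directly on this change, and no movement beyond the scatter is expected in this assay for compound 4. The expectation for compound 4 in this assay is 350 nM, with a range of 120 nM to 1000 nM. The expected step is a 1.1-fold higher number from compound 1 to compound 4 (0.04 log units; within the scatter), essentially flat.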

Compound 4, half-maximal effective concentration: 240 nM
Compound 4: the middle estimate sits 1.5-fold (0.16 log units) above what was measured; the measured number falls inside the stated range.
By their numbers in this assay, from the lowest: compounds 2, 4 and 1 (each within the scatter of the next); then compound 3.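

In this assay, among the compounds shown here, the change from 3-chlorophenyl to 4-chlorophenyl on an oxygen on an aromatic ring gives a 1.3-fold lower number from compound 1 to compound 4 (0.12 log units; within the scatter), the first measured step that relocates the chloro rather than adding one. For this pair, the location of the single chloro on the ring does not separate the two compounds in this read-out, even though the two groups match in heavy atoms and in every other count computed for them. No supporting measurement speaks to why the two placements read alike.

The compounds shown leave open whether this flat result holds for substituents other than chloro, such as methoxy or nitrile, and how an unsubstituted phenyl on the same oxygen would read. They also leave open how a trifluoromethyl group reads on a six-membered aromatic ring of carbon only, since compound 3 carries that group on a different ring and so does not separate the effect of the substituent from that of the ring.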